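The compounds below may be only part of what the source reports. "The series", "measured", "known", "first", "only" and "open" are said of these compounds alone.

Measured so far:
Compound 1 `C[C@@H]1O[C@@H](N2C(=O)/C(=C3\Nc4ccccc4C3=O)c3ccccc32)[C@H](O)[C@H](O)[C@H]1O` in a functional assay on KYSE-70 cells (Homo sapiens) for antiproliferative activity, read by crystal violet staining, with a stated time of 96 h; a lower number here means a stronger inhibitor, a higher number a weaker inhibitor: compound 1 reaches only > 25000 nM, which is a limit of the assay.
Compound 2 `C[C@@H]1O[C@H](N2C(=O)/C(=C3\Nc4ccc(Cl)cc4C3=O)c3ccccc32)[C@H](O)[C@H](O)[C@H]1O` in this assay: compound 2 gives 5940 nM.

Among the results shown, compound 2 supplies the only actual number in this assay; the one other result is a limit (the limit of > 25000 nM in this assay, at which 1 of the 2 values shown sits). Compound 3 `C[C@@H]1O[C@@H](N2C(=O)/C(=C3\Nc4ccc(Cl)cc4C3=O)c3ccccc32)[C@H](O)[C@H](O)[C@H]1O` has not yet been tested. Relative to compound 2 it changes as follows: the two compounds have the same atoms and bonds and differ only in configuration as drawn: 1 of 6 stereo elements differ; a stereocentre at a saturated ring carbon is drawn S in compound 2 and R in compound 3. Going by the values given here, no step between two measured compounds is recorded for this assay, so the size of this change cannot be read from a precedent. For a single configurational switch of this kind, a shift beyond the scatter toward weaker inhibition is expected, though a result within the scatter of compound 2 remains possible. The expected step is a 2.5-fold higher number from compound 2 to compound 3 (0.40 log units; beyond the scatter). Compound 3 is accordingly estimated to give 15000 nM in this assay, within a range of 5000 nM to 40000 nM.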

Compound 3, half-maximal inhibitory concentration: 15300 nM
The estimate for compound 3 lay 1.0-fold (0.01 log units) below the measured number, and the stated range covers the measured number.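

In this assay, switching a single stereocentre at a saturated ring carbon gives a 2.6-fold higher number from compound 2 to compound 3 (0.41 log units; beyond the scatter), the first measured sign that configuration at this position matters, and nothing else can account for the gap: the fact that compounds 2 and 3 differ only in the configuration as drawn. Chloro in place of hydrogen on an aromatic carbon gives an at least 1.6-fold lower number from compound 1 to compound 3 (0.21 log units; that floor lies within the scatter), which is a floor and not a measured size. Going by these compounds, the result for compound 1 is a limit, so the full effect of the chloro group in this configuration remains unknown: the limit of > 25000 nM in this assay, at which 1 of the 3 values shown sits.

The compounds shown leave open whether the preference for the configuration in compound 2 holds when the chloro group is replaced by hydrogen. They also leave open how a methoxy group or an amine in the place of the chloro group would affect the number.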